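A few compounds are considered here, and "the series" means these few. Any claim that something is new, unique, unknown or untested is made for them only; others in the source may bear on it.

In a functional assay on the whole organism (artery, strain albino) with Rattus norvegicus as the target, with a stated time of 600 min, at a dose of 10 mg/kg by the oral route (on this read-out higher numbers stand for more inhibition at the one dose given (going by the name of the read-out) and lower numbers for less inhibition), three compounds of one series have been measured so far. Compound 1 `COc1ccc(C2N=C(SCc3ccccc3)NC(C)=C2C(=O)Nc2ccc(F)cc2)cc1OC` gives 3.1%, and compound 2 `CC1=C(C(=O)Nc2ccc(Br)cc2)C(c2ccc(Cl)cc2Cl)N=C(SCc2ccccc2Cl)N1` gives 24.6%. Compound 3 `CC1=C(C(=O)Nc2ccc([N+](=O)[O-])cc2)C(c2ccc(Br)cc2)N=C(SCc2ccccc2)N1` gives 27.2%, the highest of the three numbers; its gap to compound 2 lies within the usual scatter, while its gap to compound 1 lies beyond it. Compound 4 `CC1=C(C(=O)Nc2ccc([N+](=O)[O-])cc2)C(c2ccc(Br)cc2)N=C(SCc2ccc(Cl)cc2)N1` has not yet been measured. It differs from compound 3 in one place: chloro in place of hydrogen on an aromatic carbon. Going by the values given here, no pair of measured compounds differs by this change alone, so nothing in the data shows its size. Only a small step, within the scatter in either direction, is expected, namely a number 0.8 percentage points higher from compound 3 to compound 4 (within the scatter). Compound 4 is accordingly estimated at 28%, with a range from 10% to 46%.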

Compound 4, a percentage reported as inhibition, in the whole organism at one dose (the size of the read-out at that dose, not a potency): 34.4%
Compound 4: the middle estimate sits 6.4 percentage points below what was measured; measured number inside the range.
By their numbers in this assay, from the lowest: compound 1; then compounds 2, 3 and 4 (each within the scatter of the next).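

Going by these compounds alone, with benzyl going to 4-chlorobenzyl on the sulfur of the shared core, this assay gives the first direct reading of this change, a number 7.2 percentage points higher from compound 3 to compound 4 (within the scatter). At this place, para to a large group, the chloro therefore does not separate compound 4 from compound 3 at the one dose given. Nothing shown bears on the cause of this small step. From the compounds shown here alone, whether an amine or a carboxylic acid on the same aromatic carbon would read differently remains open. So does whether a longer chain in place of the benzyl would change the number.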